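Series notes: three measured compounds, one pending

A few compounds are considered here, and "the series" means these few. Any claim that something is new, unique, unknown or untested is made for them only; others in the source may bear on it.

Measured so far:
compound 1 `CN(C(=O)NC(=O)c1cccc(C(F)(F)F)c1)c1nc(C(F)(F)F)c(C(=O)N/N=C/c2ccc(C(F)(F)F)cc2)s1` gives 7.71 ug/mL
compound 2 `CN(C(=O)NC(=O)c1ccccc1F)c1nc(C(F)(F)F)c(C(=O)N/N=C/c2cccc(C(F)(F)F)c2)s1` gives 20.3 ug/mL
compound 3 `CN(C(=O)NC(=O)c1ccccc1F)c1nc(C(F)(F)F)c(C(=O)N/N=C/c2ccc(C(F)(F)F)cc2)s1` gives 4.56 ug/mL

All numbers come from a functional assay on HepG2 cells (Homo sapiens) for inhibition, read by MTT assay, with a stated time of 72 h; a higher number here means a weaker inhibitor, a lower number a stronger inhibitor. In this assay compound 3 gives 4.56 ug/mL and compound 1 gives 7.71 ug/mL; the step of a 1.7-fold higher number from compound 3 to compound 1 (0.23 log units; within the scatter) corresponds to the change (3-(trifluoromethyl)phenyl in place of 2-fluorophenyl on a carbonyl carbon). Compound 2 gives 20.3 ug/mL, the highest reading of the three, and differs from compound 3 by 3-(trifluoromethyl)phenyl in place of 4-(trifluoromethyl)phenyl on a carbon with a double bond to nitrogen; the step of a 4.5-fold lower number from compound 2 to compound 3 (0.65 log units; beyond the scatter) is the only change beyond the scatter among these three.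

Compound 4 `CN(C(=O)NC(=O)c1cccc(C(F)(F)F)c1)c1nc(C(F)(F)F)c(C(=O)N/N=C/c2cccc(C(F)(F)F)c2)s1` is not yet measured in this assay. It differs from compound 2 by 3-(trifluoromethyl)phenyl in place of 2-fluorophenyl on a carbonyl carbon, the same change, at the same place, as that from compound 3 to compound 1; the two starting cores differ as described above. The step expected from compound 2 to compound 4 is a 1.3-fold higher number from compound 2 to compound 4 (0.11 log units; within the scatter). Among the compounds with values here, this rests on the single prior instance, a 1.7-fold higher number from compound 3 to compound 1 (0.23 log units; within the scatter), being within the scatter, with no second instance to show whether it holds on the core of compound 2. Compound 4 is therefore estimated at 26 ug/mL in this assay. The expected range for compound 4 runs from 11 ug/mL to 60 ug/mL.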

Compound 4, half-maximal inhibitory concentration: 5.79 ug/mL
Compound 4: middle estimate off by 4.5-fold (0.65 log units), on the high side; measured number outside the range, below it.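

On the core of compound 2, 3-(trifluoromethyl)phenyl in place of 2-fluorophenyl on a carbonyl carbon gives a 3.5-fold lower number from compound 2 to compound 4 (0.54 log units; beyond the scatter) in this assay, so this change does not carry over with the same size from one core to the other: the same change on two cores in this assay, a 1.7-fold higher number (0.23 log units; within the scatter) from compound 3 to compound 1 and a 3.5-fold lower number (0.54 log units; beyond the scatter) from compound 2 to compound 4, 5.9-fold (0.77 log units) apart, beyond the scatter of two such steps. The change between 3-(trifluoromethyl)phenyl and 4-(trifluoromethyl)phenyl on a carbon with a double bond to nitrogen gives a 1.3-fold lower number from compound 1 to compound 4 (0.12 log units; within the scatter) with the 3-(trifluoromethyl)phenyl group on the carbonyl carbon, and its size also depends on the group at that other place: the same change on two cores in this assay, a 4.5-fold lower number (0.65 log units; beyond the scatter) from compound 2 to compound 3 and a 1.3-fold higher number (0.12 log units; within the scatter) from compound 4 to compound 1, 5.9-fold (0.77 log units) apart, beyond the scatter of two such steps. These four compounds show that the two places do not act independently here, but they do not show why, and they rest on a single set of four readings.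

As far as these compounds go, whether this dependence extends beyond 2-fluorophenyl and the two trifluoromethyl-substituted phenyl groups remains open. A phenyl group carrying an amine or a carboxylic acid at either place would test it, as would a reading outside this assay.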